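Cytotoxicity in the shared core: dropping the ring chlorine

This account rests on a few compounds, and the source may have more. Where it says the series, first, only, none or still open, it means among the compounds named here.

Two compounds of this series have been run in a functional assay on MT4 cells (Homo sapiens) for cytotoxicity; a higher number here means that more compound is tolerated, a lower number that less compound is tolerated. Compound 1, `Cc1nc(S)n(Nc2ccc(F)cc2)c1-c1ccccc1`, gives 220000 nM in this assay. Compound 2, `Cc1nc(S)n(Nc2cccc(Cl)c2)c1-c1ccc(Cl)cc1`, gives 40800 nM in this assay, the lowest of the two numbers; the gap to compound 1 lies beyond the scatter, so compound 2 is the less tolerated of the pair. The two differ in more than one place, so no single structural change can be tied to that gap.

Compound 3, `Cc1nc(S)n(Nc2cccc(Cl)c2)c1-c1ccccc1`, is the next point. Relative to compound 2 it carries hydrogen in place of chloro on an aromatic carbon. The difference, taken one bond further out, reads 4-chlorophenyl to phenyl; the change sits para to a large group. Among the compounds with values here, no measured pair isolates this change, so its effect in this assay is open. Within the data shown here, compound 1, the only other number, also lacks a chlorine on that ring and is tolerated at a higher concentration, which points upward. The step of a 2.2-fold higher number from compound 2 to compound 3 (0.34 log units; beyond the scatter) is expected to be moderate and towards a higher number. Compound 3 is therefore estimated at 90000 nM in this assay, within a range from 35000 nM to 250000 nM.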

Compound 3, half-maximal cytotoxic concentration: 66700 nM
Beside the measured number, compound 3's estimate is 1.3-fold (0.13 log units) above it; measured number inside the range.
By their numbers in this assay, from the lowest: compounds 2 and 3 (each within the scatter of the next); then compound 1.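

In this assay, hydrogen in place of chloro on an aromatic carbon gives a 1.6-fold higher number from compound 2 to compound 3 (0.21 log units; within the scatter), so this first isolated reading of 4-chlorophenyl to phenyl, para to a large group, shows no difference that can be separated from the scatter. Within the data shown here, with phenyl held in common, 3-chlorophenyl in place of 4-fluorophenyl on a nitrogen on an aromatic ring gives a 3.3-fold lower number from compound 1 to compound 3 (0.52 log units; beyond the scatter), and of the two single changes now readable, only this modest step lies beyond the scatter. No available evidence bears on the reason for either step.

From the compounds shown here alone, what a methoxy group or an amine would give at the position of the chloro in 4-chlorophenyl remains open, as does whether the exchange of chloro for hydrogen reads the same with 4-fluorophenyl on the nitrogen. The step from compound 1 also alters both the halogen and its place on the ring, so the compounds shown do not tell which of the two goes with the lower number.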